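The source may hold more compounds than are shown below. What is called first, only, known or untested is meant among the compounds shown, and "the series" means these compounds.

Compound 1 `COc1ccc(/C=C2\Cc3c(cc(OC)c(OC)c3OC)C2=O)cc1` and compound 2 `COc1ccc(/C=C2\Cc3c(cc(OC)c(OC)c3OC)C2=O)cc1N` share one core, while compound 3 `COc1ccc(/C=C2\Cc3cc(OC)c(OC)c(OC)c3C2=O)cc1` and compound 4 `COc1ccc(/C=C2\Cc3cc(OC)c(OC)c(OC)c3C2=O)cc1N` share another; the difference between the two cores is not broken down here. In a functional assay on PC-3 cells (Homo sapiens) for antiproliferative activity, read by MTT assay, with a stated time of 48 h (on this read-out higher numbers stand for weaker inhibition of growth and lower numbers for stronger inhibition of growth), compound 1 gives 750 nM and compound 2 gives 456 nM. The change between them is amino in place of hydrogen on an aromatic carbon, which made a step of a 1.6-fold lower number from compound 1 to compound 2 (0.22 log units; within the scatter). For compound 3 this assay reports only a limit, > 10000 nM. The same change, (amino in place of hydrogen on an aromatic carbon), turns compound 3 into compound 4, which has not yet been measured in this assay. Within the data shown here, because the limit of > 10000 nM in this assay, at which 1 of the 3 values shown sits, is all that is known of compound 3, the earlier step is the only guide. Given the step of a 1.6-fold lower number from compound 1 to compound 2 (0.22 log units; within the scatter), which stayed within the scatter, compound 4 is expected to show a step that the limit leaves unreadable from compound 3 to compound 4. Compound 4 is therefore estimated at 12000 nM, between 4000 nM and 40000 nM, with a fair chance that only a limit is reported again.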

Compound 4, concentration for 50% growth inhibition: > 10000 nM
Compound 4: a limit, no number; the forecaster's own chance of this, stated with the estimate: 60%; the middle value is on the limit's open side.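

Compound 3 and compound 4 both stand only as limits in this assay, so no step between them can be read: the limit of > 10000 nM in this assay, at which 2 of the 4 values shown sit.

From the compounds shown here alone, whether amino in place of hydrogen changes growth inhibition on the core of compound 3 stays open.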